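Extending a Long Saturated Chain on a Shared Core

The source may report more compounds than this note shows. Statements on the series, on what has been measured and on what is new or still open speak of the compounds shown alone.

Of the compounds shown here, two built on the same core have been tested so far. Compound 1 `CCCCCCCCCCCCCCCCc1nc(N2CCC2)nc(OC2CCC2)c1O` carries a long saturated chain, and in a functional assay on cells (Lymphocyte, Homo sapiens), read by a luciferase reporter and ATP content, with a stated time of 48 h, tested at 20 uM (a lower number here means a stronger effect, a higher number a weaker effect of the compound at the concentration tested), compound 1 gives 103%. Compound 2 `CCCCCCCCCCCCCCc1nc(OC2CCC2)nc(OC2CCC2)c1O` carries a shorter chain and, in this assay, compound 2 gives 94%. For the measured compounds named here, these two numbers sit within the usual scatter of each other, so neither compound stands apart; both read close to no effect at the concentration tested, and no step between them can be drawn.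

Compound 3 `CCCCCCCCCCCCCCCCc1nc(OC2CCC2)nc(OC2CCC2)c1O` is the next compound to be measured. It is made from compound 2 by one change: ethyl in place of hydrogen on a saturated chain carbon, ten or more bonds along the chain from an aromatic carbon. Because compound 2 gives 94% and compound 1, which already carries the longer chain, gives 103%, nothing in the numbers points toward a shift in either direction. The step is therefore expected to be none beyond the scatter, so that in this assay the step from compound 2 to compound 3 is estimated at a number 4 percentage points higher from compound 2 to compound 3 (within the scatter). Compound 3 is expected to give about 98%, somewhere between 85% and 110%.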

Compound 3, a percentage reported as activity, at one concentration (the size of the read-out at that concentration, not a potency): 96%
Estimate against measurement, compound 3: 2 percentage points above; the measured number falls inside the stated range.
By their numbers in this assay, from the lowest: compounds 2, 3 and 1 (each within the scatter of the next).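

In this assay, ethyl in place of hydrogen on a saturated chain carbon, ten or more bonds along the chain from an aromatic carbon, gives a number 2 percentage points higher from compound 2 to compound 3 (within the scatter), so at this position the two chain lengths read alike. For the compounds shown here, compound 3 also provides the first comparison of a change in one place on an aromatic carbon: cyclobutyloxy in place of azetidin-1-yl gives a number 7 percentage points lower from compound 1 to compound 3 (within the scatter), and this swap likewise leaves the two compounds reading alike. No separate measurement bears on why these compounds read as they do.

All three compounds therefore sit close together, and these two changes give no handle on the read-out at the concentration tested. As far as these compounds go, whether a carboxylic acid or an amine on the chain, a much shorter chain such as butyl, or an amine in place of cyclobutyloxy on the aromatic carbon would read any differently remains open.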